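This account rests on a few compounds, and the source may have more. Where it says the series, first, only, none or still open, it means among the compounds named here.

Compound 1 `CC(C)C[C@H](NC(=O)[C@]1(Cc2ccccc2)CCN1C(=O)OCc1ccccc1)C(N)=O` and compound 3 `CC(C)C[C@H](NC(=O)[C@@]1(Cc2ccccc2)CCN1C(=O)OCc1ccccc1)C(N)=O` share the same atoms and bonds; (the two compounds have the same atoms and bonds and differ only in configuration as drawn: 1 of 2 stereo elements differ; a stereocentre at a saturated ring carbon is drawn S in compound 1 and R in compound 3). In an ADME assay on HELF cells (Homo sapiens) for cytotoxicity, with a stated time of 3 days (a lower number here means that less compound is tolerated, a higher number that more compound is tolerated), compound 1 gives 100000 nM. For compound 3 the result is only a limit of the measurement, > 100000 nM. The step is therefore a number no lower from compound 1 to compound 3 (the limit leaves the size open), and no cause for it can be taken from the fact that compounds 1 and 3 differ only in the configuration as drawn. Compound 2 `CC(C)CNC(=O)[C@H](C)NC(=O)[C@]1(Cc2ccccc2)CCN1C(=O)OCc1ccccc1` is made from compound 1 by one change: 1-(isobutylcarbamoyl)ethyl in place of 1-carbamoyl-3-methylbutyl on an amide-type nitrogen. For compound 2 the result in this assay is again only a limit of the measurement, > 100000 nM. That gives a number no lower from compound 1 to compound 2 (the limit leaves the size open), with the size hidden because of the limit of > 100000 nM in this assay, at which 2 of the 3 values shown sit.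

Compound 4 `CC(C)CNC(=O)[C@H](C)NC(=O)[C@@]1(Cc2ccccc2)CCN1C(=O)OCc1ccccc1` carries the same change on the core of compound 3: 1-(isobutylcarbamoyl)ethyl in place of 1-carbamoyl-3-methylbutyl on an amide-type nitrogen. The place of the change reads the same in both pairs, so it is the same change on a core that differs only in the drawn configuration. For compound 4 in this assay the expected step is a number no higher from compound 3 to compound 4 (the limit leaves the size open), resting on the fact that compound 1 already gives 100000 nM. Compound 3 itself has only a limit of the measurement in this assay. Compound 4 is estimated at 100000 nM, between 50000 nM and 200000 nM.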

Compound 4, minimum cytotoxic concentration: > 100000 nM
Compound 4: a limit, no number (the forecaster's own chance of this, stated with the estimate: 85%); the middle value lies on the limit itself.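

In this assay, among these compounds, compound 2, compound 3 and compound 4 each give only a limit of the measurement, so no step to compound 4 can be read. The compounds shown leave open how much compound these three tolerate, and so whether 1-(isobutylcarbamoyl)ethyl in place of 1-carbamoyl-3-methylbutyl, or the drawn configuration, changes the result at all.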